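The source may report more compounds than this note shows. Statements on the series, on what has been measured and on what is new or still open speak of the compounds shown alone.

Measured so far:
- compound 1, `COc1cc(C2=NN(C(C)=O)C(c3cccc(F)c3)O2)cc(OC)c1OC`: 16.5%
- compound 2, `COc1cc(C2=NN(C(C)=O)C(c3ccccc3C(F)(F)F)O2)cc(OC)c1OC`: -11%
- compound 3, `COc1cc(C(=O)N/N=C/c2cccc(C(F)(F)F)c2)cc(OC)c1OC`: 51%

In a functional assay on PC-3 cells (Homo sapiens) for antiproliferative activity, read by MTT assay, tested at 1 uM (a lower number here means a weaker effect, a higher number a stronger effect of the compound at the concentration tested), compound 2 gives the lowest of the three numbers, -11%. Its nearest neighbour, compound 1, gives 16.5%, and, built on a different core, compound 3 gives 51%; the gap from compound 2 to each lies beyond the scatter.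

Compound 4, `COc1cc(C2=NN(C(C)=O)C(c3ccccc3F)O2)cc(OC)c1OC`, is not yet measured. It differs from compound 2 in one place: fluoro in place of trifluoromethyl on an aromatic carbon.

Among the compounds with values here, one measured step bears on this. a number 27.5 percentage points lower from compound 1 to compound 2 (beyond the scatter), so moving the ring substituent to the place next to the large group, and enlarging it to trifluoromethyl, cost a modest amount. Compound 4 keeps the same place but returns to fluoro, so a rise of roughly that size is expected in this assay. The estimated step is a number 23 percentage points higher from compound 2 to compound 4 (beyond the scatter). Compound 4 is therefore expected to give 12%, within -2% to 28%.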

Compound 4, a percentage reported as inhibition, at one concentration (the size of the read-out at that concentration, not a potency): 13.5%
Beside the measured number, compound 4's estimate is 1.5 percentage points below it, within the range that was stated.
By their numbers in this assay, from the lowest: compound 2; then compounds 4 and 1 (each within the scatter of the next); then compound 3.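

In this assay there is a number 24.5 percentage points higher from compound 2 to compound 4 (beyond the scatter) when only the group changes, trifluoromethyl giving way to fluoro at one fixed place, ortho to a large group. The comparison of the two fluoro compounds shows a number 3 percentage points lower from compound 1 to compound 4 (within the scatter) for 2-fluorophenyl in place of 3-fluorophenyl, so these two cannot be told apart, and among these compounds the lowest number goes with 2-(trifluoromethyl)phenyl rather than with where a fluoro sits. No measurement here explains why the swap of trifluoromethyl for fluoro matters. Still open, from the compounds shown here alone, is how other groups at this place, such as chloro, methyl or an amine, would compare. Also open, going by these compounds, is whether 3-(trifluoromethyl)phenyl on this same core would behave like 2-(trifluoromethyl)phenyl or like the fluoro compounds.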